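The source may hold more compounds than are shown below. What is called first, only, known or untested is meant among the compounds shown, and "the series" means these compounds.

Of the compounds shown here, three sharing one core have been measured so far. Compound 1, with the structure `Cc1nc(-c2ccccc2)c(C(=O)N2CCN(c3cccc(C)c3C)CC2)o1`, was tested in an ADME assay on microsomes from liver (Mus musculus) for metabolic stability, read by LC-MS, with a stated time of 1 h, tested at 5 uM (on this read-out lower numbers stand for a less stable compound and higher numbers for a more stable compound), and gives 83.6%. Compound 2, `Cc1nc(-c2cccc(F)c2)c(C(=O)N2CCN(c3cc(Cl)cc(Cl)c3)CC2)o1`, gives 40.7% in this assay, and compound 3, `COc1cc(OC)cc(N2CCN(C(=O)c3oc(C)nc3-c3ccccc3F)CC2)c1`, gives 16.6%. Compound 1 therefore stands highest of the three numbers: the gap to compound 2 and the larger gap to compound 3 both lie beyond the usual scatter of repeated measurements, so compound 1 is the most stable of the three in this assay.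

Compound 4, `Cc1nc(-c2ccccc2)c(C(=O)N2CCN(c3cccc(Cl)c3)CC2)o1`, has not yet been measured. It differs from compound 1 in a single place: 3-chlorophenyl in place of 2,3-dimethylphenyl on an amine nitrogen in a ring. Among the measured compounds shown here, no direct pair of measured compounds shows this exact exchange, so the size of the step can only be estimated. The expectation is a moderate drop, a number 15.6 percentage points lower from compound 1 to compound 4 (beyond the scatter), rather than none at all. On that basis compound 4 is estimated at 68%, with a likely range from 45% to 90%.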

Compound 4, percent of the compound remaining: 2%
For compound 4 the middle estimate is 66 percentage points above the measured one, outside the stated range (below it).
By their numbers in this assay, from the lowest: compound 4; then compound 3; then compound 2; then compound 1.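

With the rest of compound 1 left unchanged, replacing 2,3-dimethylphenyl with 3-chlorophenyl on the amine nitrogen in the ring gives a large change in this assay, a number 81.6 percentage points lower from compound 1 to compound 4 (beyond the scatter), so the group at this position can strongly change the read-out. The earlier compounds shown here differed from one another in more than one place and could not tie a change to this position alone. Nothing shown here explains the size of this step.

A single exchange cannot separate the loss of 2,3-dimethylphenyl from the arrival of 3-chlorophenyl. As far as these compounds go, whether an unsubstituted phenyl, 3-methylphenyl or 2,3-dichlorophenyl at this position would give a number closer to compound 1 or to compound 4 remains open, as does whether the same exchange would have a similar effect with a fluorophenyl elsewhere on the shared core.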